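The source may hold more compounds than are shown below. What is called first, only, known or untested is meant among the compounds shown, and "the series" means these compounds.

Three compounds that share the core of compound 1 `CC(C)(C)c1ccc(C(=O)NCc2ccc(OC(F)(F)F)cc2)cc1` have been measured in an assay on HeLa cells with Bile acid receptor (Homo sapiens) as the target, read by a luciferase reporter, with a stated time of 24 h; a lower number here means that less compound is needed, a higher number that more compound is needed for the effect. Compound 1 gives 160 nM there. Compound 2 `CCOc1ccc(CNC(=O)c2ccc(C(C)(C)C)cc2)cc1` gives 160 nM in this assay. Compound 3 `CC(=O)c1ccc(CNC(=O)c2ccc(C(C)(C)C)cc2)cc1` gives 100 nM in this assay, which is the lowest of the three numbers, although a 1.6-fold lower number from compound 1 to compound 3 (0.20 log units; within the scatter) and a 1.6-fold lower number from compound 2 to compound 3 (0.20 log units; within the scatter) both stay within the scatter, as does no change at the digits printed from compound 1 to compound 2 (within the scatter). So far, every exchange of the group on that aromatic carbon has left the number essentially where it was.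

Compound 4 `CC(=O)Nc1ccc(CNC(=O)c2ccc(C(C)(C)C)cc2)cc1` is the next step from compound 3: acetamido in place of acetyl on an aromatic carbon. All three measured steps bear on this change, since each of them also exchanges the group at the same place, and none of them moved the number beyond the scatter. The expected step is therefore a 1.5-fold higher number from compound 3 to compound 4 (0.18 log units; within the scatter) in this assay, with no direction beyond the scatter anticipated. Compound 4 is estimated at 150 nM in this assay, with a range from 60 nM to 400 nM.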

Compound 4, half-maximal effective concentration: 2900 nM
Estimate against measurement, compound 4: 19-fold (1.29 log units) below; measured number above the stated range.
By their numbers in this assay, from the lowest: compounds 3, 1 and 2 (each within the scatter of the next); then compound 4.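

At this place on the aromatic ring, the group is not interchangeable after all: in this assay acetamido gives a 29-fold higher number from compound 3 to compound 4 (1.46 log units; beyond the scatter) and an 18-fold higher number from compound 2 to compound 4 (1.26 log units; beyond the scatter) and also an 18-fold higher number from compound 1 to compound 4 (1.26 log units; beyond the scatter) even though acetyl, ethoxy and trifluoromethoxy had all stayed within the scatter of one another. Among these four groups, acetamido is the only one with a hydrogen-bond donor and the only one that separates from the rest, but a single compound shows only that the two coincide. Nothing shown here accounts for the rise.

On these data alone, it remains open whether the rise belongs to the amide hydrogen or to the acetamido group as a whole, which a methylated acetamido group could help to separate. As far as these compounds go, it also remains open how an amine, a carboxylic acid or a longer acyl chain on the nitrogen would behave at this place.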